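Methoxy to hydroxy: an untested change in a short series

This account rests on a few compounds, and the source may have more. Where it says the series, first, only, none or still open, it means among the compounds named here.

Compound 1, `COc1cc(-c2nn(-c3ccc(NC(=O)Nc4ccc(Cl)c(Cl)c4)cc3)cc2-c2ccncc2)ccc1Cl`: 3440 nM
Compound 2, `COc1cc(-c2nn(-c3ccc(NC(=O)c4ccc(Cl)c(Cl)c4)cc3)cc2-c2ccncc2)ccc1Cl`: 5740 nM
Compound 3, `COc1cc(-c2nn(-c3ccc(NC(=O)c4ccc(Cl)c(C(F)(F)F)c4)cc3)cc2-c2ccncc2)ccc1Cl`: 3150 nM

The three measured compounds share one core and differ only in the group on the carbonyl carbon. Compound 1 carries a (3,4-dichlorophenyl)amino there, and in a functional assay on SK-MEL-2 cells (Homo sapiens) for antiproliferative activity, read by sulforhodamine B assay, with a stated time of 48 h (on this read-out lower numbers stand for stronger inhibition and higher numbers for weaker inhibition), compound 1 gives 3440 nM. Compound 2 carries a 3,4-dichlorophenyl, and in this assay compound 2 gives 5740 nM. Compound 3 carries a 4-chloro-3-(trifluoromethyl)phenyl, and in this assay compound 3 gives 3150 nM. Compound 2 sits within the scatter of both others: a 1.7-fold higher number from compound 1 to compound 2 (0.22 log units; within the scatter) and a 1.8-fold lower number from compound 2 to compound 3 (0.26 log units; within the scatter), and likewise a 1.1-fold lower number from compound 1 to compound 3 (0.04 log units; within the scatter). None of the three is separated from the rest.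

Compound 4 `O=C(Nc1ccc(-n2cc(-c3ccncc3)c(-c3ccc(Cl)c(O)c3)n2)cc1)c1ccc(Cl)c(Cl)c1` keeps the 3,4-dichlorophenyl amide of compound 2 and differs from it in one place: hydrogen in place of methyl on an oxygen on an aromatic ring. Among the measured compounds shown here, no measured step touches this position; every measured step lies on the carbonyl side of the molecule, and all three were within the scatter. For the measured compounds named here, the data give no direction for this change, and the only guidance is that the series so far has moved little. For compound 4 the expected step is a 1.1-fold lower number from compound 2 to compound 4 (0.06 log units; within the scatter), which is nothing beyond the scatter. The estimate for compound 4 in this assay is 5000 nM, with a range from 2000 nM to 14000 nM.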

Compound 4, half-maximal inhibitory concentration: 4050 nM
For compound 4 the middle estimate is 1.2-fold (0.09 log units) above the measured one; measured number inside the range.
By their numbers in this assay, from the lowest: compounds 3, 1, 4 and 2 (each within the scatter of the next).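

Compound 4 is the only compound shown with a change on the methoxy side of the molecule, and in this assay replacing methoxy with hydroxy gives a 1.4-fold lower number from compound 2 to compound 4 (0.15 log units; within the scatter) on the 3,4-dichlorophenyl amide. Removing the methyl from this oxygen therefore does not move the number beyond the scatter, so this position, like the carbonyl side, does not separate the compounds, and a free hydroxy is tolerated here as far as this read-out can show. No available evidence bears on this result.

Only methyl and hydrogen are shown on this oxygen, which leaves open what a longer chain such as ethyl, or an amine in place of the hydroxy, would do in this assay on the same core. On these data alone, it also remains open whether the step from methoxy to hydroxy would read the same with the (3,4-dichlorophenyl)amino group of compound 1 or the 4-chloro-3-(trifluoromethyl)phenyl group of compound 3 on the carbonyl carbon.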